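Iodoacetamide-tethered ATP analogues against hexokinase-1

The source may report more compounds than this note shows. Statements on the series, on what has been measured and on what is new or still open speak of the compounds shown alone.

Measured compounds:
compound 1, `O=C(CI)NCCCCCC(=O)NCCCCCCNc1ncnc2c1ncn2[C@@H]1O[C@H](COP(=O)(O)OP(=O)(O)OP(=O)(O)O)[C@@H](O)[C@H]1O`, 0%
compound 2, `O=C(CI)NCCCCCCC(=O)NCCCCCCNc1ncnc2c1ncn2[C@@H]1O[C@H](COP(=O)(O)OP(=O)(O)OP(=O)(O)O)[C@@H](O)[C@H]1O`, 0%
compound 3, `O=C(CI)NCCCCNc1ncnc2c1ncn2[C@@H]1O[C@H](COP(=O)(O)OP(=O)(O)OP(=O)(O)O)[C@@H](O)[C@H]1O`, 0%

Of the compounds shown here, three sharing one core have been measured in an assay on isolated protein for inhibition of hexokinase-1 (Rattus norvegicus), with a stated time of 6 h, tested at 10 mM; on this read-out higher numbers stand for more inhibition at the one concentration tested (going by the name of the read-out) and lower numbers for less inhibition. Compound 1 gives 0% in this assay, compound 2 gives 0%, and compound 3 gives 0%. Compound 3 therefore stands level with compound 1 and compound 2 at the digits shown; all three sit within the scatter of one another, so no order among them can be read.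

Compound 4, `O=C(CI)NCCC(=O)NCCCCCCNc1ncnc2c1ncn2[C@@H]1O[C@H](COP(=O)(O)OP(=O)(O)OP(=O)(O)O)[C@@H](O)[C@H]1O`, has not yet been measured. It differs from compound 3 in one place: a group of 12 heavy atoms (7 carbon, 2 nitrogen, 2 oxygen, 1 iodine; no ring) in place of a group of 5 heavy atoms (2 carbon, 1 nitrogen, 1 oxygen, 1 iodine; no ring), on a saturated chain carbon, four bonds along the chain from a nitrogen on an aromatic ring. The incoming group is, by its name, the same sort of amide-linked iodoacetamide chain that compound 1 and compound 2 carry.

Among the measured compounds shown here, only one measured step exists, no change at the digits printed from compound 1 to compound 2 (within the scatter), and it lengthens the chain in the part of the molecule that compound 4 acquires. Since compound 1 is at 0%, compound 2 at 0%, and compound 3 at 0%, nothing here indicates that putting such a chain onto the core moves this assay beyond the scatter. Compound 4 is therefore expected to show no change at the digits printed from compound 3 to compound 4 (within the scatter). The estimate for compound 4 in this assay is 0%, with a range from 0% to 10%.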

Compound 4, a percentage reported as inhibition, at one concentration (the size of the read-out at that concentration, not a potency): 0%
The estimate for compound 4 equals the measured number at the digits printed; the measured number falls inside the stated range.
By their numbers in this assay, from the lowest: compounds 1, 2, 3 and 4 (each within the scatter of the next).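

In this assay, among the compounds shown here, the longer amide-linked chain at this position, on a saturated chain carbon, four bonds along the chain from a nitrogen on an aromatic ring, gives no change at the digits printed from compound 3 to compound 4 (within the scatter) and so adds the first direct comparison at this site, where the shared core had so far offered only a change in chain length further out. Shortening that chain, with ((iodomethyl)carbonyl)amino in place of 4-(((iodomethyl)carbonyl)amino)butyl or of 3-(((iodomethyl)carbonyl)amino)propyl, gives no change at the digits printed from compound 2 to compound 4 (within the scatter) and no change at the digits printed from compound 1 to compound 4 (within the scatter) in the same read-out, so the flat result of the earlier lengthening step now holds over a wider span of chain lengths. Nothing available accounts for this flat result.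

All four compounds give the same reading, so the series offers no order among them and no sign of which part of the molecule, if any, could move this read-out. Going by these compounds, whether an amine or a carboxylic acid in place of the ((iodomethyl)carbonyl)amino end, or a chain longer than that of compound 2, would lift the reading remains open.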